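Anilide variation on a shared chromone-free core series

The compounds below may be only part of what the source reports. "The series", "measured", "known", "first", "only" and "open" are said of these compounds alone.

Of the compounds shown here, two have numbers so far. Compound 1 `COc1ccc(CNC(=O)/C=C/c2coc3cc(O)ccc3c2=O)cc1` in a functional assay on Huh-7 cells (Homo sapiens) for inhibition, read by MTT assay, with a stated time of 48 h (a higher number here means a weaker inhibitor, a lower number a stronger inhibitor), gives 8430 nM. Compound 2 `COc1ccc2c(=O)c(/C=C/C(=O)Nc3cc(C)ccc3C)coc2c1` in this assay gives 11100 nM, the higher of the two numbers, though the gap to compound 1 lies within the scatter, so the two cannot be ordered. Among the compounds with values here, no step between compounds differing in a single place has been measured, and the two measured compounds differ in more than one place, so nothing is known yet about how a change on the amide-type nitrogen moves the number.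

Compound 3 `COc1ccc2c(=O)c(/C=C/C(=O)Nc3ccc(F)cc3)coc2c1` is not yet measured. It differs from compound 2 by 4-fluorophenyl in place of 2,5-dimethylphenyl on an amide-type nitrogen. Within the data shown here, with no comparable step on record, the expected step from compound 2 to compound 3 is a 1.1-fold lower number from compound 2 to compound 3 (0.05 log units; within the scatter), that is, nothing beyond the scatter in either direction. Compound 3 is therefore estimated at 10000 nM in this assay, with a range from 4000 nM to 25000 nM.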

Compound 3, half-maximal inhibitory concentration: 33900 nM
Estimate against measurement, compound 3: 3.4-fold (0.53 log units) below; measured number outside the range, above it.
By their numbers in this assay, from the lowest: compounds 1 and 2 (each within the scatter of the next); then compound 3.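

Within the data shown here, this is the first single-place comparison: in this assay, 4-fluorophenyl in place of 2,5-dimethylphenyl on an amide-type nitrogen gives a 3.1-fold higher number from compound 2 to compound 3 (0.48 log units; beyond the scatter), so the number responds to the aryl group carried at this position. The two groups match in ring type, in hydrogen-bond donors and acceptors and in net charge, so the step goes with the ring substituents alone. No measurement at hand bears on why the number moves.

From the compounds shown here alone, the exchange removes the two methyl groups and adds the fluorine at once, and which of these carries the step stays open. Also open, going by these compounds, is how a cyclohexyl group, or a phenyl bearing an amine or a carboxylic acid, would behave on this nitrogen.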